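The source may hold more compounds than are shown below. What is called first, only, known or untested is meant among the compounds shown, and "the series" means these compounds.

Measured in an ADME assay on HEK293 cells (Homo sapiens) for cytotoxicity, read by CCK-8 assay, with a stated time of 48 h; a higher number here means a weaker inhibitor, a lower number a stronger inhibitor:
- compound 1 `COc1ccc(/C=C\c2cc(OC)c(OC)c(OC)c2)cc1OCc1ccc(C=O)cc1`: 46000 nM
- compound 2 `COc1ccc(/C=C\c2cc(OC)c(OC)c(OC)c2)cc1OCc1ccc(CNCCO)cc1`: > 50000 nM

Compound 2 has no number, only the limit > 50000 nM; that is the limit of > 50000 nM in this assay, at which 1 of the 2 values shown sits. Compound 3 `COc1ccc(/C=C\c2cc(OC)c(OC)c(OC)c2)cc1OCc1ccc(CO)cc1` carries hydroxy in place of (2-hydroxyethyl)amino on a saturated chain carbon bound to an aromatic carbon. Within the data shown here, one measured step bears on this: an at least 1.0-fold higher number from compound 1 to compound 2 (0.03 log units; that floor lies within the scatter). It stays within the scatter, so no step beyond the scatter, in either direction, is expected in this assay. The expected change is an at least 1.2-fold lower number from compound 2 to compound 3 (0.09 log units; that floor lies within the scatter). The estimate for compound 3 is 40000 nM, with an expected range of 15000 nM to 60000 nM.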

Compound 3, half-maximal inhibitory concentration: 37000 nM
For compound 3 the middle estimate is 1.1-fold (0.03 log units) above the measured one; measured number inside the range.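

In this assay, hydroxymethyl in place of formyl on an aromatic carbon gives a 1.2-fold lower number from compound 1 to compound 3 (0.09 log units; within the scatter), so the two measured values at this position do not separate. Hydroxy in place of (2-hydroxyethyl)amino on a saturated chain carbon bound to an aromatic carbon gives an at least 1.3-fold lower number from compound 2 to compound 3 (0.13 log units; that floor lies within the scatter). Compound 2 has only a limit, so that step is a floor and its full size cannot be read: the limit of > 50000 nM in this assay, at which 1 of the 3 values shown sits.

What the compounds shown leave open is whether a carboxylic acid or a primary amine on that aromatic carbon would give a step beyond the scatter.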